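Chloro in Place of Hydrogen: From Compound 3 to Compound 4

The source may hold more compounds than are shown below. What is called first, only, known or untested is meant among the compounds shown, and "the series" means these compounds.

Three compounds share a core in which a pyrazine ester is joined to a benzene ring carrying an unsaturated ester or acid. Compound 1 `CCOC(=O)/C=C/c1cc(OC)ccc1OC(=O)c1nc(C)c(C)nc1C` gives 23.4% in a functional assay on EA.hy 926 cells (Homo sapiens) for cytotoxicity, read by MTT assay, with stated times of 24 h and 12 h, tested at 25 uM; on this read-out lower numbers stand for a weaker effect and higher numbers for a stronger effect at the one concentration tested. Compound 2 `Cc1nc(C)c(C(=O)Oc2ccc(Cl)cc2/C=C/C(=O)O)nc1C` gives 26% in this assay. Compound 3 `CCOC(=O)/C=C/c1ccccc1OC(=O)c1nc(C)c(C)nc1C` gives 17.8% in this assay; its number is the lowest of the three shown, yet its distances to compound 1 and to compound 2 both lie within the scatter, so the three cannot be ranked.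

Compound 4 `CCOC(=O)/C=C/c1cc(Cl)ccc1OC(=O)c1nc(C)c(C)nc1C` differs from compound 3 by chloro in place of hydrogen on an aromatic carbon. Within the data shown here, the one measured step at the same place, a number 5.6 percentage points lower from compound 1 to compound 3 (within the scatter), shows that exchanging a group on this aromatic carbon moved the read-out only within the scatter. Compound 2 also carries a chloro on its ring, but it differs from compound 3 in more than one place, so its value alone cannot be read as a step.

On this basis, compound 4 is expected to change from compound 3 by a number 6.2 percentage points higher from compound 3 to compound 4 (within the scatter), which is within the scatter. Compound 4 is therefore estimated at 24%, with a range from 15% to 33%.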

Compound 4, a percentage reported as activity, at one concentration (the size of the read-out at that concentration, not a potency): 62.5%
Estimate against measurement, compound 4: 38.5 percentage points below, and the stated range ends below it.
By their numbers in this assay, from the lowest: compounds 3, 1 and 2 (each within the scatter of the next); then compound 4.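

Among these compounds, on this aromatic carbon, chloro in place of hydrogen gives a number 44.7 percentage points higher from compound 3 to compound 4 (beyond the scatter) in this assay, the first step to lie beyond the scatter, so the read-out can respond strongly to a change at this position. Chloro in place of methoxy at the same carbon gives a number 39.1 percentage points higher from compound 1 to compound 4 (beyond the scatter), so the large rise belongs to chloro rather than to any group placed here, while ethyl in place of hydrogen on an oxygen next to a carbonyl group gives a number 36.5 percentage points higher from compound 2 to compound 4 (beyond the scatter), so the chloro compound reaches this level only with the ethyl present. Nothing available explains the size of these steps.

Going by these compounds, it remains open whether bromo or an amine on this carbon would give a similar number. On these data alone, whether a longer chain in place of the ethyl would keep it is equally open.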